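Adding a Methyl to the Second Alkoxy Chain

The compounds below may be only part of what the source reports. "The series", "measured", "known", "first", "only" and "open" are said of these compounds alone.

Of the compounds shown here, two have been measured so far in an ADME assay on microsomes from liver (Homo sapiens) for metabolic stability; on this read-out lower numbers stand for slow clearance and higher numbers for fast clearance. Compound 1 `CCOc1cc([C@](O)(CCN(C)C)[C@@H](c2cc3cc(Br)ccc3nc2OC)c2ccnc(OC)c2OC)cc(OC)n1` gives 3.8 uL/min in this assay. Among the compounds with values here, compound 2 `COc1cc([C@](O)(CCN(C)C)[C@@H](c2cc3cc(Br)ccc3nc2OC)c2ccnc(OC)c2OC)cc(OC(C)C)n1` gives 6.4 uL/min in this assay, and the only measured step, a 1.7-fold higher number from compound 1 to compound 2 (0.23 log units; within the scatter), lies within the scatter, so the two numbers cannot be told apart with confidence. Compound 3 `CCOc1cc([C@](O)(CCN(C)C)[C@@H](c2cc3cc(Br)ccc3nc2OC)c2ccnc(OC)c2OC)cc(OC(C)C)n1` has not yet been measured. Within the data shown here, it differs from compound 2 by methyl in place of hydrogen on a saturated chain carbon bound to an oxygen on an aromatic ring, the same kind of change as in the one measured step, only one bond closer to the ring oxygen. Because a 1.7-fold higher number from compound 1 to compound 2 (0.23 log units; within the scatter) stayed within the scatter, a step of similar size and direction is expected here, giving an estimated 1.3-fold higher number from compound 2 to compound 3 (0.12 log units; within the scatter) for compound 3 in this assay. Compound 3 is therefore estimated at 8.5 uL/min, within a range from 4 uL/min to 18 uL/min.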

Compound 3, intrinsic clearance in a liver preparation (reported as CLH), per the amount of preparation that the assay uses: 1.8 uL/min
Beside the measured number, compound 3's estimate is 4.7-fold (0.67 log units) above it, outside the stated range (below it).
By their numbers in this assay, from the lowest: compound 3; then compounds 1 and 2 (each within the scatter of the next).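

In this assay, replacing the methoxy group at this place with ethoxy gives a 3.6-fold lower number from compound 2 to compound 3 (0.55 log units; beyond the scatter), and replacing it with isopropoxy gives a 2.1-fold lower number from compound 1 to compound 3 (0.32 log units; beyond the scatter). Both steps are modest but beyond the scatter, whereas the earlier 1.7-fold higher number from compound 1 to compound 2 (0.23 log units; within the scatter), which keeps that methoxy group, was not. Adding a single methyl at a saturated chain carbon bound to an oxygen on an aromatic ring can therefore lower the number here, and compound 3, with ethoxy and isopropoxy together, sits lowest of the three. Nothing available explains this drop.

From the compounds shown here alone, it remains open whether a longer chain such as butoxy, or a ring such as cyclopropyl on the same oxygen, would lower the number further or reverse the step.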